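Triazole thioethers on prostate carcinoma cells: first notes

This account rests on a few compounds, and the source may have more. Where it says the series, first, only, none or still open, it means among the compounds named here.

Compound 1 `CCCc1nnc(SCc2ccccc2Cl)n1N1C(=O)c2ccccc2C1=O` and compound 2 `C=CCSc1nnc(-c2cc(OC)c(OC)c(OC)c2)n1N1C(=O)c2ccccc2C1=O` share one core. In a functional assay on PC-3M cells (Homo sapiens) for cytotoxicity, read by MTT assay, with a stated time of 48 h (a lower number here means a stronger inhibitor, a higher number a weaker inhibitor), compound 1 gives > 200000 nM, which is a limit of the assay and not a number. Compound 2 gives > 200000 nM in this assay, again a limit. Both sit at the limit of > 200000 nM in this assay, at which 2 of the 2 values shown sit, so compound 2 stands level with compound 1 on the numbers shown. Compound 3 `COc1cc(-c2nnc(SCC(=O)c3ccc(Cl)cc3)n2N2C(=O)c3ccccc3C2=O)cc(OC)c1OC` differs by (4-chlorophenyl)carbonyl in place of vinyl on a saturated chain carbon bound to a sulfur. Without a measured step to lean on, the expected change is an at least 1.3-fold lower number from compound 2 to compound 3 (0.12 log units; that floor lies within the scatter), within the scatter, and a limit may again be reported. Compound 3 is estimated at 150000 nM, ranging from 30000 nM to 400000 nM.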

Compound 3, half-maximal inhibitory concentration: 20700 nM
Compound 3: middle estimate off by 7.2-fold (0.86 log units), on the high side, outside the stated range (below it).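

Among these compounds, on a saturated chain carbon bound to a sulfur, (4-chlorophenyl)carbonyl in place of vinyl gives the first measured number: in this assay the change produces an at least 9.6-fold lower number from compound 2 to compound 3 (0.98 log units; beyond the scatter). This shows that the group on the sulfur side chain can shift the read-out in this assay. The step gives only a floor, as compound 2 stands at a limit of the assay and not at a number: the limit of > 200000 nM in this assay, at which 2 of the 3 values shown sit.

Going by these compounds, whether the carbonyl, the aromatic ring or the chlorine carries the change stays open. A plain phenylcarbonyl or a benzyl group at this place would separate these parts.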